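A few compounds are considered here, and "the series" means these few. Any claim that something is new, unique, unknown or untested is made for them only; others in the source may bear on it.

Compound 1 `C/N=C(\NC#N)Nc1cccnc1` is measured in a functional assay on the whole organism (blood, strain Wistar-Okamoto) with Rattus norvegicus as the target, with a stated time of 5 days (a lower number here means that less compound is needed, a higher number that more compound is needed for the effect), only as a limit, > 50 mg/kg, which is a bound of the assay and not a number.
Compound 2 `CC(C)C/N=C(\NC#N)Nc1cccnc1` gives 20 mg/kg in this assay.
Compound 3 `N#CN/C(=N\C1CC1)Nc1cccnc1` gives 20 mg/kg in this assay.

Compound 3 stands level with compound 2, since no change at the digits printed from compound 2 to compound 3 (within the scatter). Against compound 1 only a limit is available, so the step of an at least 2.5-fold lower number from compound 1 to compound 3 (0.39 log units; beyond the scatter) is known only as a lower bound on its size, and the same holds for an at least 2.5-fold lower number from compound 1 to compound 2 (0.39 log units; beyond the scatter).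

Compound 4 `CCC(C)(CC)/N=C(\NC#N)Nc1cccnc1` differs from compound 3 in one place: 1-ethyl-1-methylpropyl in place of cyclopropyl on a double-bonded nitrogen. Within the data shown here, the steps that bear on this change are those at the same nitrogen. Going from methyl to cyclopropyl, and from a hydrogen-bearing chain to an isopropyl-bearing chain, each lowered the number by at least a modest amount, while the swap of isobutyl for cyclopropyl changed nothing beyond the scatter. The new group is larger again, but the two larger groups already measured sit together, so the expected step of a 1.3-fold lower number from compound 3 to compound 4 (0.12 log units; within the scatter) is small, close to no change beyond the scatter. Compound 4 is therefore estimated at 15 mg/kg, with a range from 5 mg/kg to 50 mg/kg.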

Compound 4, minimum effective dose: 0.5 mg/kg
Compound 4: the middle estimate sits 30-fold (1.48 log units) above what was measured; measured number outside the range, below it.
By their numbers in this assay, from the lowest: compound 4; then compounds 2 and 3 (each within the scatter of the next). At a limit, above all of these: compound 1.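

Among these compounds, at the double-bonded nitrogen, the earlier compounds suggested little room for change, as isobutyl and cyclopropyl stood level, yet 1-ethyl-1-methylpropyl, with 6 heavy atoms and no ring, gives a large change in this assay (a 40-fold lower number from compound 3 to compound 4 (1.60 log units; beyond the scatter)) and one of the same size against the isobutyl compound (a 40-fold lower number from compound 2 to compound 4 (1.60 log units; beyond the scatter)). So the dose needed is highly sensitive to the group at this nitrogen, and the level values of the two earlier groups gave no warning of how far it could fall. Going by these compounds, compound 1 is known only as a limit (> 50 mg/kg), so the step to the newest compound (an at least 100-fold lower number from compound 1 to compound 4 (2.00 log units; beyond the scatter)) gives only the smallest size it could have, and its true size stays unknown: the limit of > 50 mg/kg in this assay, at which 1 of the 4 values shown sits.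

With a single group of this kind, the compounds shown cannot separate the effect of the carbon count from that of the branching, which a straight hexyl chain or a tert-butyl group could help to do. A dose read from the whole animal also leaves open why the number falls so sharply.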